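This account rests on a few compounds, and the source may have more. Where it says the series, first, only, none or still open, it means among the compounds named here.

Measured so far in a functional assay on CAPAN-1 cells (Homo sapiens) for antiproliferative activity, with a stated time of 72 h; a lower number here means a stronger inhibitor, a higher number a weaker inhibitor:
Compound 1 `Nc1ncnn2c([C@@H]3O[C@H](CO)[C@@H](O)[C@H]3O)cc(C#CC3CC3)c12` gives 20 nM.
Compound 2 `Nc1ncnn2c([C@@H]3O[C@H](CO)[C@@H](O)[C@H]3O)cc(C#Cc3ccc(F)cc3)c12` gives 55400 nM.
Compound 3 `Nc1ncnn2c([C@@H]3O[C@H](CO)[C@@H](O)[C@H]3O)cc(-c3ccsc3)c12` gives 56200 nM.

Among these three numbers compound 2 stands second highest. Its nearest neighbour is compound 3, reached by a 1.0-fold higher number from compound 2 to compound 3 (0.01 log units; within the scatter); its furthest is compound 1, from which it is separated by a 2800-fold higher number from compound 1 to compound 2 (3.44 log units; beyond the scatter). Compound 3 is likewise far from compound 1, as a 2800-fold higher number from compound 1 to compound 3 (3.45 log units; beyond the scatter) shows.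

Compound 4 `Nc1ncnn2c([C@@H]3O[C@H](CO)[C@@H](O)[C@H]3O)cc(-c3ccccc3Cl)c12` is not yet measured in this assay . It differs from compound 2 in one place: 2-chlorophenyl in place of 2-(4-fluorophenyl)ethynyl on an aromatic carbon. Going by the values given here, the step that bears most directly on this change is the one from compound 2 to compound 3, which also replaces the 2-(4-fluorophenyl)ethynyl group with a ring attached directly to the aromatic carbon, and it stayed within the scatter. The two large steps both lead away from compound 1, and nothing in the measured set links a directly attached six-membered ring to a low number. For compound 4 the step from compound 2 is therefore expected to be a 1.1-fold lower number from compound 2 to compound 4 (0.04 log units; within the scatter), within the scatter. Compound 4 is thus estimated at 50000 nM in this assay , with a range from 15000 nM to 150000 nM.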

Compound 4, half-maximal inhibitory concentration: 54900 nM
Beside the measured number, compound 4's estimate is 1.1-fold (0.04 log units) below it; low and high end bracket the measured number.
By their numbers in this assay, from the lowest: compound 1; then compounds 4, 2 and 3 (each within the scatter of the next).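

In this assay the 2-chlorophenyl group of compound 4 cannot be told apart from the two other groups that carry an aromatic ring at this aromatic carbon: a 1.0-fold lower number from compound 2 to compound 4 (0.00 log units; within the scatter) and a 1.0-fold lower number from compound 3 to compound 4 (0.01 log units; within the scatter) both stay within the scatter. A six-membered carbon ring attached directly thus gives the same result as the thiophen-3-yl ring and the 2-(4-fluorophenyl)ethynyl group, and compound 1 alone stands apart, with a 2700-fold higher number from compound 1 to compound 4 (3.44 log units; beyond the scatter) matching the two earlier large steps in size. Nothing measured here accounts for this.

From the compounds shown here alone, what stays open is whether the low number of compound 1 is specific to the cyclopropyl group or would also appear with a methyl group or a longer alkyl chain on the triple bond. Going by these compounds, it is equally open how an amine or a saturated ring attached directly at this carbon would compare.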